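Triazole-linked core series: trifluoromethyl on the phenyl

The source may report more compounds than this note shows. Statements on the series, on what has been measured and on what is new or still open speak of the compounds shown alone.

Compound 2 `C=C1C[C@]23C[C@@]1(O)CC[C@H]2c1cc(Br)c(O)c(C)c1[C@@H]3Cn1cc(-c2ccccc2)nn1` carries bromo on an aromatic carbon of the shared core, and in a functional assay on A549 cells (Homo sapiens) for cytotoxicity, read by MTT assay, with a stated time of 4 days (on this read-out lower numbers stand for stronger inhibition and higher numbers for weaker inhibition), compound 2 gives > 20000 nM, a limit of the assay and not a number. Compound 1 `C=C1C[C@]23C[C@@]1(O)CC[C@H]2c1ccc(O)c(C)c1[C@@H]3Cn1cc(-c2ccccc2)nn1` gives > 20000 nM, likewise a limit. Compound 3 `C=C1C[C@]23C[C@@]1(O)CC[C@H]2c1ccc(O)c(C)c1[C@@H]3Cn1cc(-c2ccc(F)cc2)nn1` gives > 20000 nM, also a limit. The steps a step that the two limits leave unreadable from compound 1 to compound 2 and a step that the two limits leave unreadable from compound 1 to compound 3 cannot be sized because of the limit of > 20000 nM in this assay, at which 3 of the 3 values shown sit. Compound 4 `C=C1C[C@]23C[C@@]1(O)CC[C@H]2c1cc(Br)c(O)c(C)c1[C@@H]3Cn1cc(-c2ccc(C(F)(F)F)cc2)nn1` differs from compound 2 by trifluoromethyl in place of hydrogen on an aromatic carbon. For the measured compounds named here, no measured step touches this phenyl position with a readable size, so nothing here points to a change beyond the scatter. Compound 4 is therefore expected to stay at the limit, with a step of a number no higher from compound 2 to compound 4 (the limit leaves the size open) estimated as none beyond the scatter. The estimate for compound 4 in this assay is 20000 nM, within 8000 nM to 60000 nM.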

Compound 4, half-maximal inhibitory concentration: 9280 nM
For compound 4 the middle estimate is 2.2-fold (0.33 log units) above the measured one; measured number inside the range.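

Among the four compounds, only compound 4 gives a readable number, so the phenyl position can move this read-out: in this assay, trifluoromethyl in place of hydrogen gives an at least 2.1-fold lower number from compound 2 to compound 4 (0.33 log units; beyond the scatter). The size is only a lower bound, as compound 2 sits at a limit of the assay. The other steps cannot be read: the limit of > 20000 nM in this assay, at which 3 of the 4 values shown sit.

From the compounds shown here alone, whether trifluoromethyl also gives a readable number without the bromo, on the core of compound 1, remains open. So does how an amine or a carboxylic acid would read on this phenyl.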